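The source may hold more compounds than are shown below. What is called first, only, known or untested is meant among the compounds shown, and "the series" means these compounds.

Measured compounds:
compound 1, `COc1cc2c(Oc3ccc(NC(=O)c4nn(-c5ccc(F)cc5)c(=O)c5ccccc45)cc3F)ccnc2cc1OCCCN1CCN(C)CC1`, 320 nM
compound 2, `COc1cc2c(Oc3ccc(NC(=O)c4nn(-c5ccc(Br)cc5)c(=O)c5ccccc45)cc3F)ccnc2cc1OCCCN1CCN(C)CC1`, 850 nM
compound 3, `COc1cc2c(Oc3ccc(NC(=O)c4nn(-c5ccc([N+](=O)[O-])cc5)c(=O)c5ccccc45)cc3F)ccnc2cc1OCCCN1CCN(C)CC1`, 2560 nM

Three compounds have been run in a functional assay on HT-29 cells (Homo sapiens) for cytotoxicity, read by MTT assay, with a stated time of 72 h; a lower number here means a stronger inhibitor, a higher number a weaker inhibitor. They share one core and differ only in the group on the aromatic ring attached to the ring nitrogen. Compound 3 gives the highest number of the three: the step of a 3.0-fold higher number from compound 2 to compound 3 (0.48 log units; beyond the scatter) separates it from its nearest neighbour, and the step of an 8.0-fold higher number from compound 1 to compound 3 (0.90 log units; beyond the scatter) from compound 1, which gives the lowest number. The step of a 2.7-fold higher number from compound 1 to compound 2 (0.42 log units; beyond the scatter) completes the picture.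

Compound 4, `COc1cc2c(Oc3ccc(NC(=O)c4nn(-c5ccc([N+](=O)[O-])cc5)c(=O)c5ccccc45)cc3F)ccnc2cc1OCCCN1CCCCC1`, keeps the nitro-bearing ring of compound 3 and changes the other end of the molecule: piperidin-1-yl in place of 4-methylpiperazin-1-yl on a saturated chain carbon, three bonds along the chain from an oxygen on an aromatic ring. None of the three measured steps touches this part of the structure; all of them concern the group on the aromatic ring. Within the data shown here, there is therefore no measured step that bears on the change from compound 3 to compound 4, and the nitro group, which accompanies the highest number in this assay , is retained.

With nothing pointing either way, the step of a 1.0-fold lower number from compound 3 to compound 4 (0.01 log units; within the scatter) is expected to stay within the scatter. Compound 4 is accordingly estimated at 2500 nM, with a range from 900 nM to 7000 nM.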

Compound 4, half-maximal inhibitory concentration: 2170 nM
Beside the measured number, compound 4's estimate is 1.2-fold (0.06 log units) above it; measured number inside the range.
By their numbers in this assay, from the lowest: compound 1; then compound 2; then compounds 4 and 3 (each within the scatter of the next).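

In this assay, piperidin-1-yl in place of 4-methylpiperazin-1-yl on a saturated chain carbon, three bonds along the chain from an oxygen on an aromatic ring, gives a 1.2-fold lower number from compound 3 to compound 4 (0.07 log units; within the scatter) and so opens a second place of variation, as compounds 1, 2 and 3 all carry 4-methylpiperazin-1-yl and differ only in the group on the aromatic ring. The leaving group has 7 heavy atoms and 2 hydrogen-bond acceptors and the entering group has 6 and 1, yet with the nitro-bearing ring held fixed this difference does not move the number beyond the scatter in this cell assay. No measurement at hand offers an explanation for this result.

The compounds shown leave open whether the same exchange would stay within the scatter with the fluoro group of compound 1 or the bromo group of compound 2 on the aromatic ring. They also leave open what morpholin-4-yl or a dimethylamino group at the end of the chain would give, and what a shorter or longer chain would do.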